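Para-substituent swap on the aryl ring: nitro for trifluoromethyl

A few compounds are considered here, and "the series" means these few. Any claim that something is new, unique, unknown or untested is made for them only; others in the source may bear on it.

For the measured compounds named here, compound 2 `O=C(CCCCCCc1nc(-c2ccc(C(F)(F)F)cc2)no1)C(F)(F)F` stands highest of the two numbers so far in an assay on isolated protein for inhibition of histone deacetylase 8 (Homo sapiens), read by fluorescence, with a stated time of 10 min (a lower number here means a stronger inhibitor, a higher number a weaker inhibitor), at 1030 nM, though its nearest neighbour compound 1 `O=C(CCCCCCc1nc(-c2ccccc2)no1)C(F)(F)F` lies within the scatter of it at 760 nM. Compound 3 `O=C(CCCCCCc1nc(-c2ccc([N+](=O)[O-])cc2)no1)C(F)(F)F` is the next entry; the change from compound 2 is nitro in place of trifluoromethyl on an aromatic carbon. Going by the values given here, only one measured step touches the same place on the ring, a 1.4-fold higher number from compound 1 to compound 2 (0.13 log units; within the scatter), and it did not rise above the scatter. Among the compounds with values here, with no step for nitro itself, no movement beyond the scatter is expected, so the step is estimated at a 1.1-fold lower number from compound 2 to compound 3 (0.06 log units; within the scatter). For compound 3 the estimate in this assay is 900 nM, range 400 nM to 2200 nM.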

Compound 3, half-maximal inhibitory concentration: 3170 nM
For compound 3 the middle estimate is 3.5-fold (0.55 log units) below the measured one; measured number outside the range, above it.
By their numbers in this assay, from the lowest: compounds 1 and 2 (each within the scatter of the next); then compound 3.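

The aromatic carbon para to a large group is not indifferent to its substituent in this assay: nitro in place of trifluoromethyl gives a 3.1-fold higher number from compound 2 to compound 3 (0.49 log units; beyond the scatter), and nitro in place of hydrogen gives a 4.2-fold higher number from compound 1 to compound 3 (0.62 log units; beyond the scatter). Of the groups compared at this carbon, only nitro has moved the number beyond the scatter. Nothing available explains this result. 

Going by these compounds, whether an amine or a carboxylic acid at this carbon would give a number nearer compound 1 or compound 3 remains open. Also open, on these data alone, is whether the nitro step would persist with a longer chain.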